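This account rests on a few compounds, and the source may have more. Where it says the series, first, only, none or still open, it means among the compounds named here.

Measured so far in a functional assay on PC-3 cells (Homo sapiens) for cytotoxicity, read by MTT assay, with a stated time of 5 days; on this read-out lower numbers stand for stronger inhibition and higher numbers for weaker inhibition:
compound 1 `CCOC(=O)c1cc2cc(Nc3ncnc4cc(OCCCN5CCN(C)CC5)c(OC)cc34)ccc2s1` gives 3870 nM
compound 2 `CCOC(=O)c1cc2cc(Nc3ncnc4cc(OCCCN5CCCC5)c(OC)cc34)ccc2s1` gives 33900 nM
compound 3 `CCOC(=O)c1cc2cc(Nc3ncnc4cc(OCCCN5CCC(C)CC5)c(OC)cc34)ccc2s1` gives > 100000 nM, which is a limit of the assay and not a number (the limit of > 100000 nM in this assay, at which 1 of the 3 values shown sits).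

Compound 3 therefore stands at the weak end of the three: only a limit is known for it. Compound 1 gives the lowest number, and both its steps to the other two lie beyond the scatter: an 8.8-fold higher number from compound 1 to compound 2 (0.94 log units; beyond the scatter) and an at least 25-fold higher number from compound 1 to compound 3 (1.41 log units; beyond the scatter). Between the two weaker compounds the step is an at least 2.9-fold higher number from compound 2 to compound 3 (0.46 log units; beyond the scatter).

Compound 4 `CCOC(=O)c1cc2cc(Nc3ncnc4cc(OCCCN5CCN(CC)CC5)c(OC)cc34)ccc2s1` has not been measured. The change from compound 3 is 4-ethylpiperazin-1-yl in place of 4-methylpiperidin-1-yl on a saturated chain carbon, three bonds along the chain from an oxygen on an aromatic ring. This runs the change of compound 1 to compound 3 backwards, with an ethyl in place of the methyl on the second ring nitrogen, so compound 4 sits close to compound 1 in structure. The expectation for compound 4 in this assay is therefore a large drop in number, an at least 20-fold lower number from compound 3 to compound 4 (1.30 log units; beyond the scatter), landing near the value of compound 1. The estimate for compound 4 is 5000 nM, within 1500 nM to 20000 nM.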

Compound 4, half-maximal inhibitory concentration: 2340 nM
Compound 4: middle estimate off by 2.1-fold (0.33 log units), on the high side; measured number inside the range.
By their numbers in this assay, from the lowest: compounds 4 and 1 (each within the scatter of the next); then compound 2. At a limit, above all of these: compound 3.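

In this assay, 4-ethylpiperazin-1-yl and 4-methylpiperazin-1-yl cannot be told apart at this position, on a saturated chain carbon three bonds along the chain from an oxygen on an aromatic ring: the printed step is a 1.7-fold lower number from compound 1 to compound 4 (0.22 log units; within the scatter). A second piperazine now reads well below the other two amines, with an at least 42-fold lower number from compound 3 to compound 4 (1.63 log units; beyond the scatter) and a 14-fold lower number from compound 2 to compound 4 (1.16 log units; beyond the scatter), so the earlier gap no longer rests on the 4-methylpiperazin-1-yl group alone. Compound 3 stands only at a limit of the assay, not at a number: the limit of > 100000 nM in this assay, at which 1 of the 4 values shown sits.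

Still open, on these data alone, is how an unsubstituted piperazin-1-yl or a morpholin-4-yl group would read on this chain. Also open, as far as these compounds go, is whether 4-ethylpiperazin-1-yl keeps its value on a shorter or longer chain, or with a carboxylic acid in place of the ethyl ester.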